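Carbamoyl for methylsulfanyl on two aryl ureas

The source may hold more compounds than are shown below. What is called first, only, known or untested is meant among the compounds shown, and "the series" means these compounds.

Compound 1 `CSc1ccc(NC(=O)Nc2cc(C)nc3ccccc23)cc1` and compound 3 `Cc1cc(NC(=O)Nc2ccc(C(N)=O)cc2)c2ccccc2n1` are measured in an ADME assay on Raji cells (Homo sapiens) for cytotoxicity, with a stated time of 72 h; on this read-out lower numbers stand for an effect already at smaller amounts and higher numbers for an effect only at larger amounts of compound. Compound 1 gives > 25000 nM, a limit of the assay rather than a number. Compound 3 gives > 25000 nM, again a limit. The change carbamoyl in place of methylsulfanyl on an aromatic carbon therefore yields a step that the two limits leave unreadable from compound 1 to compound 3. Compound 2 `CSc1ccccc1NC(=O)Nc1cc(C)nc2ccccc12` has the same atoms as compound 1 joined differently; the difference between the two cores is not broken down here. In this assay compound 2 gives > 25000 nM, also a limit. Compound 4 `Cc1cc(NC(=O)Nc2ccccc2C(N)=O)c2ccccc2n1` is not yet measured; it differs from compound 2 by carbamoyl in place of methylsulfanyl on an aromatic carbon, the same kind of change as from compound 1 to compound 3, the place here being ortho to a large group rather than para to a large group. Given (the limit of > 25000 nM in this assay, at which 3 of the 3 values shown sit), the step from compound 2 to compound 4 is expected to be a step that the limit leaves unreadable from compound 2 to compound 4. Compound 4 is estimated at 30000 nM, most probably reported once more as a limit.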

Compound 4, half-maximal effective concentration: > 25000 nM
Compound 4: only a limit was reported; the forecaster's own chance of this, stated with the estimate: 85%; the middle value is on the limit's open side.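

No new step can be read from compound 2 to compound 4, as both stand only as limits in this assay. The compounds shown leave open whether carbamoyl in place of methylsulfanyl changes this read-out at all.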